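The source may hold more compounds than are shown below. What is called first, only, known or untested is meant among the compounds shown, and "the series" means these compounds.

Compound 2 `CC(C(=O)NCc1ccc(C(F)(F)F)nc1N1CCC(C(F)(F)F)CC1)c1ccc(NS(C)(=O)=O)c(F)c1` gives the lowest of the two numbers seen so far in a functional assay on CHO-K1 cells for antagonist activity at transient receptor potential cation channel subfamily V member 1 (Homo sapiens), read by FLIPR; a lower number here means a stronger inhibitor, a higher number a weaker inhibitor: compound 2 gives 0.6 nM, whereas compound 1 `CC(C(=O)NCc1ccc(C(F)(F)F)nc1Nc1ccccc1)c1ccc(NS(C)(=O)=O)c(F)c1` gives 59.6 nM. For the measured compounds named here, the one measured step, a 99-fold lower number from compound 1 to compound 2 (2.00 log units; beyond the scatter), shows how strongly this part of the structure matters. Compound 3 `CC(C(=O)NCc1ccc(C(F)(F)F)nc1N1CCC(=O)CC1)c1ccc(NS(C)(=O)=O)c(F)c1` keeps the piperidine ring of compound 2 but changes it: 4-oxopiperidin-1-yl in place of 4-(trifluoromethyl)piperidin-1-yl on an aromatic carbon. Going by the values given here, no measured step covers this exact change, so the expectation is that compound 3 loses some of the gain, and the estimated step of a 10-fold higher number from compound 2 to compound 3 (1.00 log units; beyond the scatter) points upward. Compound 3 is therefore expected to give about 6 nM, within 1.5 nM to 30 nM.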

Compound 3, inhibition constant: 91 nM
For compound 3 the middle estimate is 15-fold (1.18 log units) below the measured one; the whole stated range lies below it.
By their numbers in this assay, from the lowest: compound 2; then compounds 1 and 3 (each within the scatter of the next).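

Keeping the piperidine ring is not enough to keep the strong inhibition: in this assay, replacing 4-(trifluoromethyl)piperidin-1-yl with 4-oxopiperidin-1-yl gives a 150-fold higher number from compound 2 to compound 3 (2.18 log units; beyond the scatter). Nor does this ring with its carbonyl improve on the anilino group, since the change between them gives only a 1.5-fold higher number from compound 1 to compound 3 (0.18 log units; within the scatter). Among these compounds, the low number goes with the trifluoromethyl-bearing ring alone, and no measurement here accounts for the difference. On these data alone, it remains open whether an unsubstituted piperidin-1-yl, 4-methylpiperidin-1-yl or 4-hydroxypiperidin-1-yl group would stay close to compound 2 or fall back towards compound 3.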